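Swapping a Chlorophenyl Thiourea for a Methoxyphenyl Urea

A few compounds are considered here, and "the series" means these few. Any claim that something is new, unique, unknown or untested is made for them only; others in the source may bear on it.

Two measured compounds set the scene in a functional assay on RS4-11 cells (Homo sapiens) for inhibition, read by CCK-8 assay, with a stated time of 48 h; a lower number here means a stronger inhibitor, a higher number a weaker inhibitor. Compound 1 `O=S(=O)(NCCNC(=S)Nc1ccc(Cl)cc1)c1ccc(-c2ccccc2OCc2ccccc2)s1` ends in a thiourea. In this assay compound 1 reaches only the limit of measurement, giving > 50000 nM, which is a boundary and not a number (the limit of > 50000 nM in this assay, at which 1 of the 2 values shown sits). Compound 2 `COc1ccc(Oc2cc(C)ccc2-c2ccsc2S(=O)(=O)NCCNC(=O)Nc2cc(C(F)(F)F)cc(C(F)(F)F)c2)cc1OC`, built on a different core and ending in a urea, gives 5600 nM in this assay. Compound 3 `COc1ccc(NC(=O)NCCNS(=O)(=O)c2ccc(-c3ccccc3OCc3ccccc3)s2)cc1` keeps the core of compound 1 and changes one place: a group of 11 heavy atoms (8 carbon, 1 nitrogen, 2 oxygen; one six-membered aromatic ring of carbon only) in place of a group of 10 heavy atoms (7 carbon, 1 nitrogen, 1 sulfur, 1 chlorine; one six-membered aromatic ring of carbon only), on an amine nitrogen. For the measured compounds named here, no measured pair shows this exact change, so its effect is open. Because compound 1 sits at the limit (the limit of > 50000 nM in this assay, at which 1 of the 2 values shown sits), a measured value for compound 3 can only stay at the limit or move toward stronger inhibition. A modest gain is expected, so the step of an at least 1.6-fold lower number from compound 1 to compound 3 (0.22 log units; that floor lies within the scatter) is the estimate. Compound 3 is therefore expected at 30000 nM, within a range from 8000 nM to 100000 nM.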

Compound 3, half-maximal inhibitory concentration: > 20000 nM
Compound 3: a limit, no number; the forecaster's own chance of this, stated with the estimate: 45%; the middle value does not contradict the limit.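

For the compounds shown here, compound 1 and compound 3 both stop at a limit in this assay and not at a number, so no step between them can be read. Going by these compounds, whether the (4-methoxyphenyl)carbamoyl group changes inhibition at all, compared with the group it replaces, stays open.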